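The source may hold more compounds than are shown below. What is called first, only, known or untested is meant among the compounds shown, and "the series" means these compounds.

Measured compounds in an assay on Sf9 cells for inhibition of protein deacetylase HDAC6 (Homo sapiens), read by fluorescence, with a stated time of 40 min, tested at 100 nM; on this read-out lower numbers stand for less inhibition and higher numbers for more inhibition at the one concentration tested (going by the name of the read-out):
- compound 1, `O=C(NO)c1ccc(NCc2nc(-c3ccccc3)nn2-c2ccccc2Cl)cc1`, gives 64.6%
- compound 2, `O=C(NO)c1ccc(NCc2nc(-c3ccc(Br)cc3)nn2-c2ccccc2)cc1`, gives 54.7%
- compound 3, `Cc1ccc(-n2nc(-c3ccccc3)nc2CNc2ccc(C(=O)NO)cc2)cc1`, gives 60.7%

Compound 2 has the lowest of the three numbers, yet its distance to compound 3 and its distance to compound 1 both lie within the usual scatter, so the three compounds cannot be ordered on these values. The unmeasured compound 4, `O=C(NO)c1ccc(NCc2nc(-c3ccncc3)nn2-c2ccccc2)cc1`, differs from compound 2 in one place: pyridin-4-yl in place of 4-bromophenyl on an aromatic carbon. Within the data shown here, the only measured step in this set, a number 3.9 percentage points lower from compound 1 to compound 3 (within the scatter), concerns the group on the aromatic nitrogen, not the aromatic carbon changed here, and it was within the scatter; no measured step bears directly on the change from compound 2 to compound 4. Among the measured compounds shown here, with three numbers that all sit within the scatter of one another and no step at the relevant position, the expectation for compound 4 is a step of a number 0.3 percentage points higher from compound 2 to compound 4 (within the scatter), that is, none beyond the scatter. Compound 4 is therefore estimated at 55%, within a range from 40% to 70%.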

Compound 4, a percentage reported as inhibition, at one concentration (the size of the read-out at that concentration, not a potency): 30.8%
For compound 4 the middle estimate is 24.2 percentage points above the measured one, and the stated range ends above it.
By their numbers in this assay, from the lowest: compound 4; then compounds 2, 3 and 1 (each within the scatter of the next).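

In this assay the step at this position is a number 23.9 percentage points lower from compound 2 to compound 4 (beyond the scatter) and, unlike the step on the aromatic nitrogen, it lies beyond the scatter. The aromatic carbon between two ring nitrogen atoms is thus shown to be a place where a change of group can move this read-out, which the earlier compounds did not show. The exchange replaces a ring of carbon only bearing a bromine with a ring holding one hetero atom and one hydrogen-bond acceptor, and no evidence on why the number falls is available.

The compounds shown leave open whether the lower number goes with the ring nitrogen or with the loss of the bromine. They also leave open how pyridin-3-yl, 4-aminophenyl or 4-carboxyphenyl would read at this place.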